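The source may hold more compounds than are shown below. What is called first, only, known or untested is meant among the compounds shown, and "the series" means these compounds.

Measured set in a functional assay on CHO cells with adenosine receptor A1 (Homo sapiens) as the target, read by cAMP accumulation and immunoassay, with a stated time of 6 min, tested at 1 uM; on this read-out higher numbers stand for a weaker effect at the one concentration tested and lower numbers for a stronger effect:
compound 1 `COc1ccc(N2CCN(Cc3csc(N)c3C(=O)c3ccc(Cl)cc3)CC2)cc1` gives -15%
compound 2 `Nc1scc(CN2CCN(c3cccc(C(F)(F)F)c3)CC2)c1C(=O)c1ccc(Cl)cc1` gives -72%
compound 3 `Nc1scc(CN2CCN(c3ccc(Cl)c(C(F)(F)F)c3)CC2)c1C(=O)c1ccc(Cl)cc1` gives -47%

Compound 1 stands highest of the three in this assay, its nearest neighbour being compound 3 and the furthest compound 2, and both gaps lie beyond the scatter. The two steps away from compound 1 are a number 57 percentage points lower from compound 1 to compound 2 (beyond the scatter) and a number 32 percentage points lower from compound 1 to compound 3 (beyond the scatter); the two halogenated aryl compounds are separated by a number 25 percentage points higher from compound 2 to compound 3 (beyond the scatter).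

Compound 4 `Nc1scc(CN2CCN(c3cccc(F)c3F)CC2)c1C(=O)c1ccc(Cl)cc1` differs from compound 1 by 2,3-difluorophenyl in place of 4-methoxyphenyl on an amine nitrogen in a ring. Both measured steps from compound 1 bear on this change: each exchanges 4-methoxyphenyl on an amine nitrogen in a ring for a halogenated phenyl without a hydrogen-bond acceptor, and each lowers the number beyond the scatter, one by a large and one by a somewhat smaller amount. 2,3-Difluorophenyl is a halogenated phenyl of the same kind, with no hydrogen-bond acceptor, so a downward step beyond the scatter is expected, sized between those two. The expected step from compound 1 is a number 30 percentage points lower from compound 1 to compound 4 (beyond the scatter). Compound 4 is accordingly estimated at -45%, with a range from -72% to -18%.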

Compound 4, a percentage reported as activity, at one concentration (the size of the read-out at that concentration, not a potency): -66%
For compound 4 the middle estimate is 21 percentage points above the measured one; the range from low to high includes it.
By their numbers in this assay, from the lowest: compounds 2 and 4 (each within the scatter of the next); then compound 3; then compound 1.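

In this assay, 2,3-difluorophenyl in place of 4-methoxyphenyl gives a number 51 percentage points lower from compound 1 to compound 4 (beyond the scatter), so trifluoromethyl is not required at this position for a large downward step from compound 1. Among the halogenated phenyl groups the result splits: a number 6 percentage points higher from compound 2 to compound 4 (within the scatter) leaves 2,3-difluorophenyl and 3-(trifluoromethyl)phenyl not told apart, whereas a number 19 percentage points lower from compound 3 to compound 4 (beyond the scatter) separates 2,3-difluorophenyl from 4-chloro-3-(trifluoromethyl)phenyl. No measurement at hand gives a reason for these steps.

Only 4-methoxyphenyl carries a hydrogen-bond acceptor here, so the series cannot separate the loss of that acceptor from the gain of halogen. An unsubstituted phenyl, or a phenyl bearing a nitrile or an amine, would bear on that question.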